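This account rests on a few compounds, and the source may have more. Where it says the series, first, only, none or still open, it means among the compounds named here.

Measured so far:
compound 1, `Nc1ncnc2c1c(-c1cnc3[nH]ccc3c1)nn2CCCC(=O)NO`, > 150000 nM
compound 2, `Nc1nc2cc(-c3nn(CC(=O)NO)c4ncnc(N)c34)ccc2o1`, 12200 nM

Both were tested in a functional assay on CNE-2 cells (Homo sapiens) for inhibition, read by MTT assay, with a stated time of 72 h; on this read-out lower numbers stand for stronger inhibition and higher numbers for weaker inhibition. For compound 1 the value > 150000 nM is a limit of the assay rather than a number, as noted in the limit of > 150000 nM in this assay, at which 1 of the 2 values shown sits. For the measured compounds named here, compound 2 therefore gives the only actual number, 12200 nM in this assay. The unmeasured compound 3, `Nc1nc2cc(-c3nn(CCCCCCC(=O)NO)c4ncnc(N)c34)ccc2o1`, differs from compound 2 by 5-(hydroxycarbamoyl)pentyl in place of hydroxycarbamoyl on a saturated chain carbon bound to an aromatic nitrogen. Going by the values given here, with no measured step of this kind to lean on, the change is expected to move the value by a 4.1-fold lower number from compound 2 to compound 3 (0.61 log units; beyond the scatter), towards stronger inhibition. Compound 3 is therefore estimated at 3000 nM, with a range from 500 nM to 15000 nM.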

Compound 3, half-maximal inhibitory concentration: 4360 nM
The estimate for compound 3 lay 1.5-fold (0.16 log units) below the measured number, and the stated range covers the measured number.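

Across this assay, the series now has a measured step for this change, on a saturated chain carbon bound to an aromatic nitrogen: 5-(hydroxycarbamoyl)pentyl in place of hydroxycarbamoyl gives a 2.8-fold lower number from compound 2 to compound 3 (0.45 log units; beyond the scatter). The longer chain, which keeps the same end group, therefore moves the value modestly towards stronger inhibition. Nothing shown gives a reason for this step.

As far as these compounds go, it remains open whether a shorter or a still longer chain would give a stronger or weaker value. A carboxylic acid in place of the hydroxycarbamoyl end would test how much that end group contributes.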